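The compounds below may be only part of what the source reports. "The series", "measured", "known", "first", "only" and "open" are said of these compounds alone.

Two compounds of this series share one core and differ only in the group on the carbonyl carbon of the amide. Compound 1 `COc1cc(/C=C/C(=O)c2cccc(NC(=O)c3ccc(Cl)cc3)c2)ccc1O` carries a 4-chlorophenyl there and in a functional assay on HUVEC cells (Homo sapiens) for inhibition, tested at 10 ug/mL (a higher number here means a stronger effect of the compound at the concentration tested, a lower number a weaker effect), compound 1 gives 66%. Among the compounds with values here, compound 2 `COc1cc(/C=C/C(=O)c2cccc(NC(=O)c3ccco3)c2)ccc1O` carries a furan-2-yl and in this assay compound 2 gives 100%, which is the higher of the two numbers; the step of a number 34 percentage points higher from compound 1 to compound 2 (beyond the scatter) is the only measured step and lies beyond the scatter.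

Compound 3 `COc1cc(/C=C/C(=O)c2cccc(NC(=O)c3ccc(Cl)cc3Cl)c2)ccc1O` differs from compound 2 as follows: 2,4-dichlorophenyl in place of furan-2-yl on a carbonyl carbon. Within the data shown here, this move runs counter to the measured step, since it takes the furan-2-yl away again and puts back a chlorinated phenyl, and only that step bears on it. A downward step in this assay is therefore expected, roughly of the size seen between compound 1 and compound 2. For compound 3 the expected step is a number 35 percentage points lower from compound 2 to compound 3 (beyond the scatter). In this assay compound 3 is estimated at 65%, with a range from 40% to 90%.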

Compound 3, a percentage reported as inhibition, at one concentration (the size of the read-out at that concentration, not a potency): 70%
Beside the measured number, compound 3's estimate is 5 percentage points below it; the measured number falls inside the stated range.
By their numbers in this assay, from the lowest: compounds 1 and 3 (each within the scatter of the next); then compound 2.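

In this assay there is a number 30 percentage points lower from compound 2 to compound 3 (beyond the scatter) and so a second chlorinated phenyl on this carbonyl carbon also gives a lower number than the furan-2-yl; the gap is thus not particular to the 4-chlorophenyl of compound 1. Within the data shown here, the added chloro itself shows no effect that this read-out can resolve, with a number 4 percentage points higher from compound 1 to compound 3 (within the scatter) for the only change between these two phenyl amides. Nothing at hand explains why the furan-2-yl and the two chlorinated phenyls part in this way.

Still open, as far as these compounds go, is whether the high number belongs to the furan-2-yl itself or to five-membered aromatic rings more widely, which a thiophene or a pyrrole in this place could decide. Also open, from the compounds shown here alone, is how a plain phenyl without chlorine, or a phenyl carrying an amine, would read here.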